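Acyl variation on the piperidine amide of the shared core

The compounds below may be only part of what the source reports. "The series", "measured", "known", "first", "only" and "open" are said of these compounds alone.

Measured compounds:
Compound 1 `Cc1nc(S(C)(=O)=O)ccc1Oc1ncnc(OC2CCN(C(=O)OC3CCC3)CC2)c1F`: 167 nM
Compound 2 `Cc1nc(S(C)(=O)=O)ccc1Oc1ncnc(OC2CCN(C(=O)C(C)(C)F)CC2)c1F`: 296 nM

In a functional assay on isolated protein for inhibition of Glucose-dependent insulinotropic receptor (Rattus norvegicus), read by HTRF and cAMP accumulation (a higher number here means that more compound is needed for the effect, a lower number that less compound is needed), compound 1 gives 167 nM and compound 2 gives 296 nM; the step of a 1.8-fold higher number from compound 1 to compound 2 (0.25 log units; within the scatter) lies within the scatter, so the two values show no ordered difference. Compound 2 stands as the higher of the two numbers, with compound 1 nearest.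

Compound 3 `CCC(F)(F)C(=O)N1CCC(Oc2ncnc(Oc3ccc(S(C)(=O)=O)nc3C)c2F)CC1` differs from compound 2 only in the acyl group: 1,1-difluoropropyl in place of 1-fluoro-1-methylethyl on a carbonyl carbon. Within the data shown here, the one step that bears on this position, a 1.8-fold higher number from compound 1 to compound 2 (0.25 log units; within the scatter), was within the scatter, so no step beyond the scatter is expected here either; the estimated step is a 1.0-fold higher number from compound 2 to compound 3 (0.01 log units; within the scatter). For compound 3 the expected value is 300 nM, with a range from 140 nM to 650 nM.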

Compound 3, half-maximal effective concentration: 69.2 nM
Compound 3: middle estimate off by 4.3-fold (0.64 log units), on the high side; measured number outside the range, below it.
By their numbers in this assay, from the lowest: compound 3; then compounds 1 and 2 (each within the scatter of the next).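

In this assay, this acyl position can move the number beyond the scatter, which the first pair did not show: 1,1-difluoropropyl in place of 1-fluoro-1-methylethyl gives a 4.3-fold lower number from compound 2 to compound 3 (0.63 log units; beyond the scatter). The same group in place of cyclobutyloxy gives a 2.4-fold lower number from compound 1 to compound 3 (0.38 log units; beyond the scatter), leaving compound 3 lowest of the three. No measurement here explains the change.

The compounds shown leave open whether the lower number follows the two fluorines or the chain. Plain propyl and the longer 1,1-difluorobutyl would separate these two readings.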